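The source may report more compounds than this note shows. Statements on the series, on what has been measured and on what is new or still open speak of the compounds shown alone.

Measured so far:
compound 1 `Cc1n[nH]cc1-c1cccc2c1CCC2c1ncc[nH]1` — 634 nM
compound 2 `c1cc(-c2ncco2)c2c(c1)C(c1ncc[nH]1)CC2` — 1390 nM
compound 3 `COc1cccc2c1CCC2c1ncc[nH]1` — > 10000 nM

All three were run in a functional assay on CHO cells for agonist activity at Alpha-1D adrenergic receptor (Homo sapiens), read by FLIPR and calcium flux; a lower number here means that less compound is needed, a higher number that more compound is needed for the effect. For compound 3 the assay reports only a limit, > 10000 nM, not a number. Compound 3 therefore sits at the limit of > 10000 nM in this assay, at which 1 of the 3 values shown sits, the weakest point the series reaches; compound 1 and compound 2 both return numbers, and the gap between those two is a 2.2-fold higher number from compound 1 to compound 2 (0.34 log units; beyond the scatter).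

The next compound is compound 4 `Cn1nccc1-c1cccc2c1CCC2c1ncc[nH]1`. Against compound 3 the change is 1-methyl-1H-pyrazol-5-yl in place of methoxy on an aromatic carbon. Among the compounds with values here, two measured steps bear on it, both in the opposite direction: an at least 15-fold higher number from compound 1 to compound 3 (1.19 log units; beyond the scatter) and an at least 7.1-fold higher number from compound 2 to compound 3 (0.85 log units; beyond the scatter). In each of these a five-membered aromatic ring on that aromatic carbon was replaced by methoxy and the number rose out of range; in the step to compound 4 a five-membered aromatic ring returns to that position. A large step downward in this assay is therefore expected, of the order seen for compound 1 and compound 2, with the exact size uncertain because compound 3 is a limit. The expected step from compound 3 to compound 4 is an at least 10-fold lower number from compound 3 to compound 4 (1.00 log units; beyond the scatter). Compound 4 is estimated at 1000 nM, with a likely range of 300 nM to 4000 nM.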

Compound 4, half-maximal effective concentration: > 10000 nM
Compound 4: a limit, no number; the forecaster's own chance of this, stated with the estimate: 10%; at least 10-fold (1.00 log units) between middle value and limit.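

In this assay, a five-membered aromatic ring on this aromatic carbon does not by itself give a measurable response, and compound 4, with 1-methyl-1H-pyrazol-5-yl in that place, joins compound 3 at a limit of the assay rather than a number: the limit of > 10000 nM in this assay, at which 2 of the 4 values shown sit.

Within the data shown here, what matters is therefore which ring is attached and how, not only that a ring is present, as seen in an at least 15-fold higher number from compound 1 to compound 4 (1.19 log units; beyond the scatter) and in an at least 7.1-fold higher number from compound 2 to compound 4 (0.85 log units; beyond the scatter). The step between compound 3 and compound 4 cannot be read, since both ends are limits, so methoxy and 1-methyl-1H-pyrazol-5-yl cannot be ordered.

Compound 1 and compound 4 differ both in where the methyl group sits and in how the pyrazole ring is attached, and the compounds shown do not separate these two changes. On these data alone, it also stays open how a 1H-pyrazol-4-yl without the methyl group, an aminomethyl group or a carboxylic acid on this aromatic carbon would read in this assay.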